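Swapping the aryl group on the amine nitrogen

The compounds below may be only part of what the source reports. "The series", "measured", "known", "first", "only" and "open" are said of these compounds alone.

- compound 1 `Fc1ccccc1NCn1nc(-c2ccc3c(c2)OCCO3)oc1=S`: 6390 nM
- compound 2 `FC(F)(F)c1ccccc1NCn1nc(-c2ccc3c(c2)OCCO3)oc1=S`: 9220 nM

In a functional assay, with a stated time of 6 min (a higher number here means a weaker inhibitor, a lower number a stronger inhibitor), compound 1 gives 6390 nM and compound 2 gives 9220 nM. Among the measured compounds shown here, these are the only two numbers so far, and they cannot be told apart, so compound 1 stands level with its sole neighbour.

Compound 3 `S=c1oc(-c2ccc3c(c2)OCCO3)nn1CNc1ccc(Cl)cc1` has not yet been measured. It differs from compound 1 by 4-chlorophenyl in place of 2-fluorophenyl on an amine nitrogen, which in words is 4-chlorophenyl in place of 2-fluorophenyl on an amine nitrogen.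

For the measured compounds named here, only one measured step bears on this change: a 1.4-fold higher number from compound 1 to compound 2 (0.16 log units; within the scatter), which puts trifluoromethyl in place of fluoro on an aromatic carbon. That step is a different swap and offers only indirect guidance, yet it stayed small. Going by the values given here, no measured compound carries 4-chlorophenyl, so the evidence is thin and the range must stay wide. No shift beyond the scatter is therefore expected in this assay.

The expected change is a 1.2-fold lower number from compound 1 to compound 3 (0.07 log units; within the scatter).

For compound 3 the estimated value is 5500 nM, with an expected range of 1800 nM to 14000 nM.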

Compound 3, half-maximal inhibitory concentration: 7270 nM
Compound 3: the middle estimate sits 1.3-fold (0.12 log units) below what was measured; measured number inside the range.
By their numbers in this assay, from the lowest: compounds 1, 3 and 2 (each within the scatter of the next).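

In this assay, replacing 2-fluorophenyl with 4-chlorophenyl on the amine nitrogen gives a 1.1-fold higher number from compound 1 to compound 3 (0.06 log units; within the scatter). The earlier step only exchanged fluoro for trifluoromethyl, whereas this one replaces the whole aryl group with another of the same heavy-atom count, and the number still cannot be told apart from that of compound 1. Compounds 1, 2 and 3 therefore all lie within the scatter of one another, so across these three aryl groups this position shows no measurable preference, and no measurement at hand offers a reason for that.

As far as these compounds go, all three compounds carry a phenyl ring bearing fluoro, trifluoromethyl or chloro, so it remains open whether a quite different group on this nitrogen, such as a methoxyphenyl, a pyridine or a saturated cyclohexyl ring, would move the number beyond the scatter. The shared core is also identical throughout, so these compounds cannot say how much of the activity depends on the aryl group at all, or whether changing the core, for instance putting oxygen in place of its sulfur, would matter more.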